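Pyrimidin-2-yl in Place of Pyridin-2-yl on a Shared Core

The compounds below may be only part of what the source reports. "The series", "measured", "known", "first", "only" and "open" are said of these compounds alone.

Three compounds built on one shared core were tested in a functional assay on MCF7 cells (Homo sapiens) for inhibition, read by sulforhodamine B assay, with a stated time of 48 h; a higher number here means a weaker inhibitor of growth, a lower number a stronger inhibitor of growth. Compound 1 `COC(=O)c1sc2cc(Nc3ccc(OC)cc3)cnc2c1N` gives 124000 nM in this assay. Compound 2 `COC(=O)c1sc2cc(Nc3nccc4ccccc34)cnc2c1N` does not yield a number in this assay; for compound 2 the result is a limit of the assay, > 150000 nM. Compound 3 `COC(=O)c1sc2cc(Nc3ccccn3)cnc2c1N` also does not yield a number; for compound 3 the result is likewise a limit, > 150000 nM. Among the measured compounds shown here, compound 3 therefore stands among the results that are only limits, a situation described by the limit of > 150000 nM in this assay, at which 2 of the 3 values shown sit, and no step between measured compounds that differ in one place exists to guide the next change.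

Compound 4 `COC(=O)c1sc2cc(Nc3ncccn3)cnc2c1N` differs from compound 3 by pyrimidin-2-yl in place of pyridin-2-yl on a nitrogen on an aromatic ring. Since compound 3 is reported only as a limit > 150000 nM, the account can give no direction with confidence. The step in this assay is expected to be a step that the limit leaves unreadable from compound 3 to compound 4, none beyond the scatter, with the assay most likely again reporting only a limit. Compound 4 is accordingly estimated at 200000 nM, with a range from 80000 nM to 500000 nM.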

Compound 4, concentration for 50% growth inhibition: > 150000 nM
Compound 4: no number, only a limit; the forecaster's own chance of this, stated with the estimate: 70%; the middle value does not contradict the limit.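

In this assay compound 4 gives only a limit of the assay, > 150000 nM. Compound 3 is also reported only as a limit, so no step can be read between compound 3 and compound 4. Limits now make up most of the results: the limit of > 150000 nM in this assay, at which 3 of the 4 values shown sit.

The compounds shown leave open whether pyrimidin-2-yl in place of pyridin-2-yl changes growth inhibition at all.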